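Adding a Second Methoxy Group to an Aminophenyl Enone

This account rests on a few compounds, and the source may have more. Where it says the series, first, only, none or still open, it means among the compounds named here.

Compound 1, `COc1ccc(-c2cc(/C=C/C(=O)c3ccc(N)cc3)[nH]n2)cc1`, was tested in a functional assay on NCI-H322M cells (Homo sapiens) for inhibition, read by sulforhodamine B assay, with a stated time of 48 h; on this read-out higher numbers stand for weaker inhibition of growth and lower numbers for stronger inhibition of growth. In this assay, within the data shown here, compound 1 gives 9270 nM, the highest of the two numbers measured so far. Among the measured compounds shown here, the only other compound with a number is compound 2, `COc1ccc(C(=O)/C=C/c2cc(-c3cc(OC)c(OC)c(OC)c3)n[nH]2)cc1OC`, and in this assay compound 2 gives 2900 nM, which is lower than the number of compound 1 by a margin beyond the usual scatter; the two structures differ in several places, so this gap cannot be traced to any single change.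

Compound 3, `COc1ccc(-c2cc(/C=C/C(=O)c3ccc(N)cc3)[nH]n2)cc1OC`, is the unmeasured compound of interest. It differs from compound 1 by methoxy in place of hydrogen on an aromatic carbon. For the measured compounds named here, no pair of measured compounds isolates this exact change, so the size of the step is not known from any directly comparable pair. Compound 2, the more heavily methoxylated of the two measured compounds, carries the lower number, but that is a loose hint rather than a step. Compound 3 is therefore expected to show a modest lowering of the number, roughly at the edge of the scatter, with the estimated step of a 1.5-fold lower number from compound 1 to compound 3 (0.19 log units; within the scatter). The estimate for compound 3 is 6000 nM, with a range from 2500 nM to 14000 nM.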

Compound 3, concentration for total growth inhibition: 16500 nM
Compound 3: the middle estimate sits 2.8-fold (0.44 log units) below what was measured; the measured number lies above the stated range.
By their numbers in this assay, from the lowest: compound 2; then compounds 1 and 3 (each within the scatter of the next).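

Among these compounds, this is the first pair that isolates a single change on the shared core: methoxy in place of hydrogen on an aromatic carbon of the six-membered aromatic ring of carbon only, ortho to a methoxy group and meta to a large group. In this assay the change gives a 1.8-fold higher number from compound 1 to compound 3 (0.25 log units; within the scatter) and so compounds 1 and 3 cannot be told apart on this read-out, which means that this one pair offers no sign that a methoxy group at this position moves the concentration for total growth inhibition beyond the usual variation between repeated measurements. Nothing measured on these compounds explains the size of this step, and the reading rests on a single pair on a single cell line.

The compounds shown leave open whether a different group at this position, such as a hydroxyl, an ethoxy group or a fluorine atom, would give a step beyond the scatter. They also leave open whether the same methoxy step would stay within the scatter on a core in which the amine of compound 1 is replaced by a carboxylic acid.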